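Ring Expansion on the Amide of Compound 1

The source may hold more compounds than are shown below. What is called first, only, known or untested is meant among the compounds shown, and "the series" means these compounds.

Compound 1 `CS(=O)(=O)c1ccc(C(=O)N2CCC(C(=O)N3CCc4ccccc43)CC2)cc1[N+](=O)[O-]` was tested in an ADME assay on HepG2 cells (Homo sapiens) for cytotoxicity, read by CellTiter-Glo and ATP content, with a stated time of 72 h (a higher number here means that more compound is needed for the effect, a lower number that less compound is needed), where compound 1 gives only a limit of the assay, > 27000 nM. Compound 2 `CS(=O)(=O)c1ccc(C(=O)NCCCC(=O)N2CCC(c3ccccc3)CC2)cc1[N+](=O)[O-]` likewise gives only a limit, > 27000 nM. Compound 3 `CS(=O)(=O)c1ccc(C(=O)NCCC(=O)N2CCc3ccccc3C2)cc1[N+](=O)[O-]` also returns a limit, > 27000 nM. Within the data shown here, all three thus sit at the limit of > 27000 nM in this assay, at which 3 of the 3 values shown sit, so no measured step between them exists. Compound 4 `CS(=O)(=O)c1ccc(C(=O)N2CCC(C(=O)N3CCc4ccccc4C3)CC2)cc1[N+](=O)[O-]` is not yet measured; it differs from compound 1 by 1,2,3,4-tetrahydroisoquinolin-2-yl in place of 2,3-dihydro-1H-indol-1-yl on a carbonyl carbon. Given that compound 1 shows > 27000 nM, the expected step in this assay is none beyond the scatter. For compound 4 the expected value is 40000 nM, ranging from 20000 nM to 100000 nM. The implied step is estimated as a step that the limit leaves unreadable from compound 1 to compound 4.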

Compound 4, half-maximal effective concentration: > 27000 nM
Compound 4: no number, only a limit; the forecaster's own chance of this, stated with the estimate: 85%; the middle value lies beyond the limit too.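

In this assay, among these compounds, compound 4 gives only a limit, > 27000 nM, so no step from compound 1 to compound 4 can be read: the limit of > 27000 nM in this assay, at which 4 of the 4 values shown sit. On these data alone, what concentration compound 1, compound 2, compound 3 or compound 4 would need for the effect stays open.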